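The source may report more compounds than this note shows. Statements on the series, on what has been measured and on what is new or still open speak of the compounds shown alone.

Of the compounds shown here, three from this series have been tested, and a fourth awaits its number. Compound 3 `COc1cc(OC)c(/C=C(/SCc2ccc(F)cc2)C(=O)c2ccc(Br)cc2)c(OC)c1` carries a (4-fluorobenzyl)sulfanyl group on a double-bonded chain carbon bound to a carbonyl carbon and a double-bonded chain carbon; in a functional assay on DU-145 cells (Homo sapiens) for inhibition, read by trypan blue exclusion, with a stated time of 96 h (a higher number here means a weaker inhibitor of growth, a lower number a stronger inhibitor of growth), compound 3 gives 1000 nM. Compound 2 `COc1cc(OC)c(/C=C(\C(=O)c2ccc(Br)cc2)S(=O)(=O)Cc2ccc(Cl)cc2)c(OC)c1` differs from it only by (4-chlorobenzyl)sulfonyl in place of (4-fluorobenzyl)sulfanyl on a double-bonded chain carbon bound to a carbonyl carbon and a double-bonded chain carbon, and that single change produced a 25-fold higher number from compound 3 to compound 2 (1.40 log units; beyond the scatter), so compound 2 gives 25000 nM. Compound 1 `COc1ccc(/C=C(/SCc2ccc(F)cc2)C(=O)c2ccc(Cl)cc2)c(OC)c1OC` shares much with compound 3, but the difference between the two cores is not broken down here; in this assay compound 1 gives 10000 nM. Compound 4 `COc1ccc(/C=C(\C(=O)c2ccc(Cl)cc2)S(=O)(=O)Cc2ccc(Cl)cc2)c(OC)c1OC` stands to compound 1 exactly as compound 2 stands to compound 3, the change being ((4-chlorobenzyl)sulfonyl in place of (4-fluorobenzyl)sulfanyl on a double-bonded chain carbon bound to a carbonyl carbon and a double-bonded chain carbon). Since the same change on the core of compound 3 gave a 25-fold higher number from compound 3 to compound 2 (1.40 log units; beyond the scatter), a step of similar size is expected from compound 1, namely a 15-fold higher number from compound 1 to compound 4 (1.18 log units; beyond the scatter), though compound 1 already sits at a weak level and the assay may only report a limit. The estimate for compound 4 is 150000 nM, expected to fall between 40000 nM and 500000 nM.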

Compound 4, concentration for 50% growth inhibition: 10000 nM
The estimate for compound 4 lay 15-fold (1.18 log units) above the measured number; measured number outside the range, below it.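

In this assay, the same swap of groups gave no change at the digits printed from compound 1 to compound 4 (within the scatter), so a large effect on one core did not carry over to the other: the same change on two cores in this assay, a 25-fold higher number (1.40 log units; beyond the scatter) from compound 3 to compound 2 and no change at the digits printed (within the scatter) from compound 1 to compound 4, 25-fold (1.40 log units) apart, beyond the scatter of two such steps The result shows that, in this series, the step measured on one core cannot simply be added to a compound built on another. It does not show which difference between the two cores matters, since they differ in more than one place, and the swap itself alters both the sulfur group and the halogen, while two pairs of compounds give no rule for any further core.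

The compounds shown leave open how (4-fluorobenzyl)sulfonyl would behave on each core, a comparison that would separate the change at sulfur from the change of halogen. They also leave open whether a benzyl group carrying a nitrile or an amine instead of a halogen would follow either core's result.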